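The compounds below may be only part of what the source reports. "The series", "measured", "known", "first", "only" and "open" are said of these compounds alone.

Measured compounds:
Compound 1 `CN1[C@@H]2c3[nH]c4ccccc4c3C[C@H]1[C@H](C#N)N1[C@@H](CNC(=O)c3cccc(C(F)(F)F)c3)c3[nH]c4ccccc4c3C[C@@H]21`: 870 nM
Compound 2 `CN1[C@@H]2c3[nH]c4ccccc4c3C[C@H]1[C@H](C#N)N1[C@@H](CNC(=O)c3cccc4c3CCCC4)c3[nH]c4ccccc4c3C[C@@H]21`: 3540 nM
Compound 3 `CN1[C@@H]2c3[nH]c4ccccc4c3C[C@H]1[C@H](C#N)N1[C@@H](CNC(=O)c3ccc4ccccc4n3)c3[nH]c4ccccc4c3C[C@@H]21`: 80 nM

In a functional assay on BGC-823 cells (Homo sapiens) for cytotoxicity, read by MTT assay, with a stated time of 72 h (on this read-out higher numbers stand for weaker inhibition and lower numbers for stronger inhibition), compound 3 gives the lowest number of the three measured compounds. Going by the values given here, its advantage over its nearest neighbour, compound 1, is an 11-fold lower number from compound 1 to compound 3 (1.04 log units; beyond the scatter), and over compound 2 it is a 44-fold lower number from compound 2 to compound 3 (1.65 log units; beyond the scatter); both gaps lie beyond the scatter, so compound 3 is the strongest inhibitor among the compounds measured so far.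

Compound 4 `CN1[C@@H]2c3[nH]c4ccccc4c3C[C@H]1[C@H](C#N)N1[C@@H](CNC(=O)c3cc4ccccc4s3)c3[nH]c4ccccc4c3C[C@@H]21` differs from compound 3 in one place: 1-benzothiophen-2-yl in place of quinolin-2-yl on a carbonyl carbon. All three measured steps bear on this position. Each of them exchanges the group on that carbonyl carbon. They show that this group moves the number a great deal: a 4.1-fold higher number from compound 1 to compound 2 (0.61 log units; beyond the scatter) was modest, while an 11-fold lower number from compound 1 to compound 3 (1.04 log units; beyond the scatter) and a 44-fold lower number from compound 2 to compound 3 (1.65 log units; beyond the scatter) were large. The new group keeps two fused aromatic rings but loses the ring nitrogen of quinolin-2-yl, so the expectation is a weaker result than compound 3, though not as weak as compound 2. For compound 4 the estimated step in this assay is a 3.8-fold higher number from compound 3 to compound 4 (0.57 log units; beyond the scatter). Compound 4 is therefore expected to give about 300 nM, with a range from 80 nM to 1200 nM.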

Compound 4, half-maximal inhibitory concentration: 240 nM
Estimate against measurement, compound 4: 1.3-fold (0.10 log units) above; measured number inside the range.
By their numbers in this assay, from the lowest: compound 3; then compound 4; then compound 1; then compound 2.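

In this assay the exchange of quinolin-2-yl for 1-benzothiophen-2-yl gives a 3.0-fold higher number from compound 3 to compound 4 (0.48 log units; beyond the scatter) and so costs some activity, but the new group still compares well with the other two: the change gives a 15-fold lower number from compound 2 to compound 4 (1.17 log units; beyond the scatter) and a 3.6-fold lower number from compound 1 to compound 4 (0.56 log units; beyond the scatter) in the other direction. A group of two fused aromatic rings on this carbonyl carbon therefore gives the two lowest numbers of the four compounds, whether its hetero atom is the nitrogen of quinolin-2-yl or the sulfur of 1-benzothiophen-2-yl. Nothing available explains why these groups differ.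

Going by these compounds, it remains open whether benzofuran-2-yl, with oxygen in the five-membered ring, or indol-2-yl, with a ring nitrogen bearing hydrogen, would give numbers close to these two. Also open, on these data alone, is whether an amine or a carboxylic acid added to quinolin-2-yl would lower the number further.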